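Working notes: from compound 2 to compound 4

The compounds below may be only part of what the source reports. "The series", "measured", "known", "first", "only" and "open" are said of these compounds alone.

Among the compounds with values here, in a physicochemical assay for lipophilicity (on this read-out higher numbers stand for higher lipophilicity and lower numbers for lower lipophilicity), compound 2 (`CC(C)=CCC/C(C)=C/CC/C(C)=C/CSC[C@H](NC(=O)CCCCCN1CCCC1)C(=O)NC1CCCC1`) gives 4.04, the lowest of the three numbers so far. Compound 1 (`CC(C)=CCC/C(C)=C/CC/C(C)=C/CSC[C@H](NC(=O)CCCCCN1CCN(C)CC1)C(=O)NC1CCCCCC1`) stands at 5.44, and compound 3 (`CC(C)=CCC/C(C)=C/CC/C(C)=C/CSC[C@H](NC(=O)CCCCCN1CCN(C)CC1)C(=O)NC1CCCCCCC1`) stands at 5.88.

Compound 4 (`CC(C)=CCC/C(C)=C/CC/C(C)=C/CSC[C@H](NC(=O)CCCCCN1CCCC1)C(=O)N1CCCC1`) has not yet been measured in this assay. Its structural change from compound 2 is pyrrolidin-1-yl in place of cyclopentylamino on a carbonyl carbon. In short, pyrrolidin-1-yl takes the place of cyclopentylamino on a carbonyl carbon, and the hydrogen-bond donor counted in the leaving group is gone.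

Within the data shown here, only one measured step bears on this change: a number 0.44 log units higher from compound 1 to compound 3 (beyond the scatter). It is modest, and it involves the ring on an amide-type nitrogen, with the larger ring carrying the higher number. Compound 2 differs from compound 1 in more than one place, so their gap does not isolate any single change. Among the measured compounds shown here, no measured step removes the amide hydrogen, so that part of the change has no direct guide here.

A modest fall of similar or smaller size is therefore expected, near the edge of the usual scatter. The estimated change is a number 0.34 log units lower from compound 2 to compound 4 (beyond the scatter). For compound 4 the expected value is 3.7, with an estimated range of 3.2 to 4.2.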

Compound 4, distribution coefficient: 3.31
Compound 4: the middle estimate sits 0.39 log units above what was measured; the measured number falls inside the stated range.
By their numbers in this assay, from the lowest: compound 4; then compound 2; then compound 1; then compound 3.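

In this assay, the carbonyl carbon that carries the cyclopentylamino group now has a step of its own (a number 0.73 log units lower from compound 2 to compound 4 (beyond the scatter)), so the read-out responds to a change at this position even though the group entering, pyrrolidin-1-yl, also holds a five-membered non-aromatic ring. Within the data shown here, the earlier step from cycloheptyl to cyclooctyl changed only the ring on an amide-type nitrogen, whereas this is the first step in which the hydrogen-bond donor of the leaving group is lost, with 1 donor counted for cyclopentylamino and 0 for pyrrolidin-1-yl. The same step also takes the group from 6 heavy atoms to 5 and moves the nitrogen into the ring, so the single number cannot be divided among these differences, and nothing among the data accounts for the fall.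

Open, from the compounds shown here alone, is how much of the step goes with the amide hydrogen and how much with the ring: a cyclopentyl(methyl)amino group on the same carbonyl carbon has no amide hydrogen and keeps the carbon-only ring. A piperidin-1-yl group there would give the ring-size trend for this tertiary amide, which the compounds shown do not cover.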